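The compounds below may be only part of what the source reports. "The series", "measured", "known", "first", "only" and "open" are said of these compounds alone.

In a functional assay on HCT-116 cells (Homo sapiens) for inhibition, read by MTT assay, with a stated time of 48 h (a lower number here means a stronger inhibitor, a higher number a weaker inhibitor), compound 3 `CC/C=C/C(=O)N(Cc1ccc(OC)c(O)c1)c1cc(OC)c(OC)c(OC)c1` holds the lowest number of the two that are numbers. Compound 3 gives 63 nM, while compound 2 `C/C=C/C(=O)N(Cc1ccc(OC)c(OC)c1)c1cc(OC)c(OC)c(OC)c1` gives 32800 nM, and the gap between them lies far beyond the usual scatter. Compound 1 `COc1cc(NCc2ccccc2)cc(OC)c1OC` reaches only a limit of this assay, > 80000 nM. That value is the limit of > 80000 nM in this assay, at which 1 of the 3 values shown sits. Among the measured compounds shown here, no two measured compounds differ in a single place, so no single step can be read off; compound 2 and compound 3 differ both in the chain on the carbonyl carbon and in the benzyl part, and the two differences cannot be separated.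

Compound 4 `COc1ccc(CN(C(=O)C2CC2)c2cc(OC)c(OC)c(OC)c2)cc1O` is the one still to be measured in this assay. It departs from compound 3 in one place: cyclopropyl in place of but-1-en-1-yl on a carbonyl carbon. Nothing measured here shows how a change at this carbonyl carbon alone moves the number. A modest weakening, a 4.0-fold higher number from compound 3 to compound 4 (0.60 log units; beyond the scatter), is expected, since the bulk of compound 3 is kept. Compound 4 is therefore estimated at 250 nM, within a range from 60 nM to 1500 nM.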

Compound 4, half-maximal inhibitory concentration: 49 nM
The estimate for compound 4 lay 5.1-fold (0.71 log units) above the measured number; measured number outside the range, below it.
By their numbers in this assay, from the lowest: compounds 4 and 3 (each within the scatter of the next); then compound 2. At a limit, above all of these: compound 1.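

In this assay, among the compounds shown here, the first comparison in one place reads a 1.3-fold lower number from compound 3 to compound 4 (0.11 log units; within the scatter), with cyclopropyl in place of but-1-en-1-yl on a carbonyl carbon. At this position, then, a three-membered ring of carbon takes the place of an open chain with one double bond, and the number stays within the scatter, so for this pair neither the open chain nor its double bond is required to keep the number where it stands. Nothing available here bears on this result or gives a reason for it.

The compounds shown leave open whether a longer chain, an amine or a carboxylic acid on this carbonyl carbon would keep the number as well as cyclopropyl does. Also open, as far as these compounds go, is how much of the gap between compound 2 and compound 3 belongs to the benzyl part alone, as those two differ in more than one place.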